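Piperidine replacing the arylamine on the shared core

A few compounds are considered here, and "the series" means these few. Any claim that something is new, unique, unknown or untested is made for them only; others in the source may bear on it.

Compound 1 `Cc1ccc(NC2=CC(=O)c3nc4n(c3C2=O)[C@H]2OC[C@@H](O)[C@H]2OC4)cc1C` stands lowest of the three numbers in a functional assay on ECa-109 cells for inhibition, with ECa-109 cell line (Homo sapiens) as the target, read by sulforhodamine B assay (on this read-out higher numbers stand for weaker inhibition and lower numbers for stronger inhibition), where compound 1 gives 2820 nM. Compound 2 `COc1ccc(NC2=CC(=O)c3c(nc4n3[C@H]3OC[C@@H](O)[C@H]3OC4)C2=O)cc1` gives 3410 nM in this assay, and compound 3 `O=C1C=C(Nc2ccc(C(F)(F)F)cc2)C(=O)c2c1nc1n2[C@H]2OC[C@@H](O)[C@H]2OC1` gives 5500 nM; both differences from compound 1 lie within the scatter, so no order among the three can be drawn.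

Among the compounds with values here, the only single-point step recorded, a 2.0-fold higher number from compound 1 to compound 3 (0.29 log units; within the scatter), exchanges one aryl substituent pattern for another on the amine nitrogen and does not leave the scatter.

Compound 4 `O=C1C=C(N2CCCCC2)C(=O)c2c1nc1n2[C@H]2OC[C@@H](O)[C@H]2OC1` differs from compound 1 in a different way: piperidin-1-yl in place of (3,4-dimethylphenyl)amino on a double-bonded ring carbon. Within the data shown here, no measured step swaps the arylamine for a saturated ring, and no measured step removes the hydrogen-bond donor, so the recorded steps do not bear directly on this change; they show only that varying the aryl ring itself moved nothing beyond the scatter.

With nothing in the set to anchor the move, the expected outcome for compound 4 is a modest shift toward a higher number, a 2.1-fold higher number from compound 1 to compound 4 (0.33 log units; beyond the scatter), with wide uncertainty. Compound 4 is estimated at 6000 nM in this assay, within a range from 1500 nM to 25000 nM.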

Compound 4, half-maximal inhibitory concentration: > 8000 nM
Compound 4: a limit, no number; the forecaster's own chance of this, stated with the estimate: 15%; at least 1.3-fold (0.12 log units) between middle value and limit.
By their numbers in this assay, from the lowest: compounds 1, 2 and 3 (each within the scatter of the next). At a limit, above all of these: compound 4.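

Within the data shown here, at the double-bonded ring carbon, the change to piperidin-1-yl gives an at least 2.8-fold higher number from compound 1 to compound 4 (0.45 log units; beyond the scatter), the only step in the set that leaves the scatter, whereas the exchange of substituents on the aryl ring, a 2.0-fold higher number from compound 1 to compound 3 (0.29 log units; within the scatter), stays inside it. In this assay compound 4 gives > 8000 nM, which is a limit and not a number, so the step has a lower bound and no known upper end. This position is therefore not indifferent to what sits on it, which the aryl-for-aryl comparison could not show, and the reading rests on a single limit: the limit of > 8000 nM in this assay, at which 1 of the 4 values shown sits.

The change takes away the aromatic ring and the hydrogen-bond donor together, so the compounds shown leave open which of the two goes with the step. A cyclohexylamino group, which keeps the amine hydrogen on a saturated ring, and an N-methyl-N-phenylamino group, which keeps the aromatic ring without that hydrogen, would separate the two at this carbon.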